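The source may report more compounds than this note shows. Statements on the series, on what has been measured and on what is new or still open speak of the compounds shown alone.

Measured compounds in an assay on CHO cells for displacement of a labelled ligand from adenosine receptor A3 (Homo sapiens), read by scintillation counting, with a stated time of 45 min, in the presence of a further agent that is not named here; a lower number here means a stronger inhibitor, a higher number a weaker inhibitor:

Compound 1 `CCCn1c(=O)[nH]c2nc(-c3ccc(S(=O)(=O)N4CCN(C)CC4)cc3)[nH]c2c1=O` gives > 1000 nM, a limit of the assay and not a number.
Compound 2 `CCCn1c(=O)[nH]c2nc(-c3ccc(S(=O)(=O)N4CCN(c5ccccc5Cl)CC4)cc3)[nH]c2c1=O` gives > 1000 nM, likewise a limit.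
Compound 3 `CCCn1c(=O)[nH]c2nc(-c3ccc(S(=O)(=O)N4CCN(c5ccc(I)cc5)CC4)cc3)[nH]c2c1=O` gives > 1000 nM, likewise a limit.

Compound 1 thus stands only at a limit in this assay, and no number places it against its neighbours. The steps a step that the two limits leave unreadable from compound 1 to compound 2, a step that the two limits leave unreadable from compound 1 to compound 3 and a step that the two limits leave unreadable from compound 2 to compound 3 cannot be read in size because of the limit of > 1000 nM in this assay, at which 3 of the 3 values shown sit. All three differ on an amine nitrogen in a ring, where a methyl, a 2-chlorophenyl or a 4-iodophenyl sits.

Compound 4 `CCCn1c(=O)[nH]c2nc(-c3ccc(S(=O)(=O)N4CCN(Cc5cccc(C)c5)CC4)cc3)[nH]c2c1=O` differs from compound 1 by 3-methylphenyl in place of hydrogen on a saturated chain carbon bound to an amine nitrogen in a ring. Going by the values given here, none of the measured steps touches this position, and none yields a readable size, so they offer no direction for the new change. The shared core, carrying the three substituents shown, has not reached a readable value in any case shown. He therefore expects the step that the limit leaves unreadable from compound 1 to compound 4 to leave compound 4 near the same limit, and estimates compound 4 at 3000 nM, within 700 nM to 20000 nM, most likely reported again only as a limit.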

Compound 4, inhibition constant: > 1000 nM
Compound 4 ended at the assay's limit (the forecaster's own chance of this, stated with the estimate: 75%); the middle value is on the limit's open side.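

Compound 4 also stands only at a limit in this assay, so its steps from compound 1, compound 2 and compound 3 cannot be read in size: the limit of > 1000 nM in this assay, at which 4 of the 4 values shown sit. The compounds shown leave open whether any group on the amine nitrogen in a ring gives a readable value.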